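This account rests on a few compounds, and the source may have more. Where it says the series, first, only, none or still open, it means among the compounds named here.

In an ADME assay on MDCK cells (Canis lupus familiaris) for cytotoxicity (on this read-out lower numbers stand for higher toxicity in this test and higher numbers for lower toxicity in this test), two compounds have been read so far. Compound 1, `CC(=O)Nc1ccc2oc(-c3ccnc(C(=O)N4CCC5(CC4)CN(C(c4ccccc4)c4nnn(C)n4)C5)c3)nc2c1`, gives > 50000 nM, which is a limit of the assay and not a number. Compound 2, `CC(=O)Nc1ccc2oc(-c3ccnc(C(=O)N4CCN(C(c5ccc(Br)cc5)c5nnn(C)n5)CC4)c3)nc2c1`, gives > 50000 nM, which is likewise a limit and not a number. Compound 2 therefore has no exact position, only (the limit of > 50000 nM in this assay, at which 2 of the 2 values shown sit).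

Compound 3, `CC(=O)Nc1ccc2oc(-c3ccnc(C(=O)N4CCN(C(c5ccc(C(F)(F)F)cc5)c5nnn(C)n5)CC4)c3)nc2c1`, keeps the rest of compound 2 and differs in one place: trifluoromethyl in place of bromo on an aromatic carbon. This puts trifluoromethyl in place of bromo on an aromatic carbon, para to a large group, turning 4-bromophenyl into 4-(trifluoromethyl)phenyl. Within the data shown here, no measured pair shows this change, so there is no direct precedent for the size of the step. A step beyond the scatter is not expected in either direction in this assay, and another reading at the limit of the assay is the most likely outcome. The expected step is a number no higher from compound 2 to compound 3 (the limit leaves the size open). For compound 3 the estimated value is 50000 nM, with an expected range from 25000 nM to 100000 nM.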

Compound 3, half-maximal cytotoxic concentration: > 50000 nM
Compound 3: no number, only a limit (the forecaster's own chance of this, stated with the estimate: 85%); the middle value sits exactly at the limit.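

Compound 2 and compound 3 both give a limit rather than a number in this assay, so no step can be read between them, and the trifluoromethyl for bromo change stays unsized: the limit of > 50000 nM in this assay, at which 3 of the 3 values shown sit. The compounds shown leave open how far each one lies from that limit and whether any change in the series would give a number in this assay.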